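This account rests on a few compounds, and the source may have more. Where it says the series, first, only, none or still open, it means among the compounds named here.

Measured in a physicochemical assay for solubility, in phosphate buffer, with a stated time of 18 h, at pH 7; a higher number here means a more soluble compound, a lower number a less soluble compound:
- compound 1 `CC(=O)N1CCCC([C@@H]2[C@@H](C(=O)Nc3ccc(F)c(C#N)c3)c3ccccc3C(=O)N2CC(C)C)C1`: 69000 nM
- compound 2 `CC(C)CN1C(=O)c2ccccc2[C@H](C(=O)Nc2ccc(F)c(C#N)c2)[C@H]1c1ccc(C(N)=O)s1`: 19000 nM

Of these two compounds, compound 2 has the lower number, 19000 nM, and the gap to compound 1 is larger than repeat measurements would usually produce.

The next structure is compound 3 `CC(C)CN1C(=O)c2ccccc2[C@H](C(=O)Nc2ccc(F)c(C#N)c2)[C@H]1c1ccnnc1`. It keeps the shared core, and pyridazin-4-yl takes the place of 5-carbamoylthiophen-2-yl on a saturated ring carbon, next to the ring nitrogen: pyridazin-4-yl in place of 5-carbamoylthiophen-2-yl on a saturated ring carbon.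

Within the data shown here, only one measured step bears on this change, and it was made at the same ring carbon: a 3.6-fold lower number from compound 1 to compound 2 (0.56 log units; beyond the scatter). That modest step brought in the 5-carbamoylthiophen-2-yl group that now leaves. Among the measured compounds shown here, no measured compound carries pyridazin-4-yl, so this single step is thin evidence, and the direction remains uncertain. The best guess is a move back up in this assay of similarly modest size. The expected change is a 2.4-fold higher number from compound 2 to compound 3 (0.37 log units; beyond the scatter). For compound 3 the estimated value is 45000 nM, with an expected range from 14000 nM to 130000 nM.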

Compound 3, solubility: 28000 nM
The estimate for compound 3 lay 1.6-fold (0.21 log units) above the measured number, within the range that was stated.
By their numbers in this assay, from the lowest: compounds 2 and 3 (each within the scatter of the next); then compound 1.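

In this assay, putting pyridazin-4-yl in place of 5-carbamoylthiophen-2-yl gives a 1.5-fold higher number from compound 2 to compound 3 (0.17 log units; within the scatter), so at this saturated ring carbon two groups that differ in ring size, hetero atoms and hydrogen-bond donors cannot be told apart in this read-out. Among these compounds, both lie on the same side of the 1-acetylpiperidin-3-yl group, since the earlier 3.6-fold lower number from compound 1 to compound 2 (0.56 log units; beyond the scatter) is now joined by a 2.5-fold lower number from compound 1 to compound 3 (0.39 log units; beyond the scatter), which turns a single observation into two matching ones, though compound 1 remains the only compound here without an aromatic ring on this carbon. Nothing measured here offers a reason for any of these steps.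

From the compounds shown here alone, whether an aromatic ring as such separates compounds 2 and 3 from compound 1, or the acetylated piperidine is what stands apart, remains open, and a plain phenyl ring or a piperidine with a free amine on this carbon would help to separate those two readings. Going by these compounds, it is equally open whether a group bearing a carboxylic acid would stay with compounds 2 and 3 or move away from them.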